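Swapping the acetylpiperidine for a dimethylpyrazole

This account rests on a few compounds, and the source may have more. Where it says the series, first, only, none or still open, it means among the compounds named here.

Compound 1, `Cc1ncccc1-c1cnc(NCc2c(F)ccc3c2CCO3)c2n[nH]c(=O)n12`, gives 2.5.
Compound 2, `CN(C)Cc1ccc(C(=O)Nc2cnc(NCc3c(F)ccc4c3CCO4)n3cnnc23)cc1`, gives 1.8.
Compound 3, `CC(=O)N1CCC(c2cnc(NCc3c(F)ccc4c3CCO4)c3cn[nH]c(=O)c23)CC1`, gives 2.9.

These three values come from a physicochemical assay for lipophilicity, using the shake flask method, in phosphate buffer, measured as octanol-water partition, with a stated time of 30 min, at pH 7.4; on this read-out higher numbers stand for higher lipophilicity and lower numbers for lower lipophilicity. Among them compound 3 stands highest: its nearest neighbour is compound 1, lower by a margin beyond the scatter, and compound 2 lies furthest, more than a full unit below it.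

The step under consideration leads from compound 3 to compound 4, `Cc1nn(C)cc1-c1cnc(NCc2c(F)ccc3c2CCO3)c2cn[nH]c(=O)c12`, which has not yet been measured in this assay. The change is 1,3-dimethyl-1H-pyrazol-4-yl in place of 1-acetylpiperidin-4-yl on an aromatic carbon. The group that leaves has one six-membered non-aromatic ring with one hetero atom and a double bond outside aromatic rings; the group that enters is a five-membered aromatic ring with two hetero atoms, two heavy atoms fewer in all.

For the measured compounds named here, no measured pair differs in this way alone, so the size of the step can only be judged from the change itself. The step from compound 3 to compound 4 in this assay is expected to be small, a number 0.30 log units lower from compound 3 to compound 4 (within the scatter), no larger than the scatter, with a downward lean at most. For compound 4 the estimated value is 2.6, with a range from 2.1 to 3.1.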

Compound 4, distribution coefficient: 2.8
Compound 4: middle estimate off by 0.20 log units, on the low side, within the range that was stated.
By their numbers in this assay, from the lowest: compound 2; then compounds 1, 4 and 3 (each within the scatter of the next, the first and the last beyond it).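

In this assay, placing 1,3-dimethyl-1H-pyrazol-4-yl instead of 1-acetylpiperidin-4-yl on this aromatic carbon gives a number 0.10 log units lower from compound 3 to compound 4 (within the scatter), so the two compounds cannot be told apart on this read-out. For the compounds shown here, this is the first comparison that isolates a single place, since no earlier pair differed in one place alone, and it shows that at this position a five-membered aromatic ring with 2 hetero atoms and a six-membered non-aromatic ring with 1 hetero atom and a double bond outside aromatic rings can be exchanged with no step beyond the scatter, despite the change from 9 to 7 heavy atoms. Nothing available explains why the two groups give so similar a result.

This single step leaves open whether the position would respond as little to a group of another kind, such as an unsubstituted piperidine, a primary amine or a carboxylic acid. It also leaves open whether the same exchange would give a similar step on the core of compound 1 or of compound 2.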